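Removing one bromopropyl chain from a terthiophene

This account rests on a few compounds, and the source may have more. Where it says the series, first, only, none or still open, it means among the compounds named here.

Three compounds share a core of linked five-membered sulfur rings, each carrying bromine-bearing chains at the ends. Compound 1 `BrCCCc1ccc(-c2ccc(CCCBr)s2)s1` has two rings, compound 2 `BrCCCCc1ccc(-c2ccc(-c3ccc(-c4ccc(CCCCBr)s4)s3)s2)s1` four rings with longer chains, and compound 3 `BrCCCc1ccc(-c2ccc(-c3ccc(CCCBr)s3)s2)s1` three rings with 3-bromopropyl groups. The property followed is an ADME assay on MDCK cells (Canis lupus familiaris) for cytotoxicity, read by MTT assay, with a stated time of 2 days; a higher number here means that more compound is tolerated, a lower number that less compound is tolerated. In this assay compound 1 gives "not determined" (no result reported). Compound 2 likewise gives "not determined" (no result reported). For compound 3 the result is > 200000 nM, which is a limit of the assay rather than a number. Among the three entries, compound 3 therefore sits at the limit of > 200000 nM in this assay, at which 1 of the 3 values shown sits, and the other two entries carry no single number at all, so there is no pair of measured compounds to compare.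

Compound 4 `BrCCCc1ccc(-c2ccc(-c3cccs3)s2)s1` is the next compound. It differs from compound 3 in one place (hydrogen in place of 3-bromopropyl on an aromatic carbon). Among the compounds with values here, with no completed step, the expectation must rest on compound 3 alone, whose > 200000 nM shows only that a high amount was tolerated. The expected step from compound 3 to compound 4 is a number no higher from compound 3 to compound 4 (the limit leaves the size open), that is, no change beyond the usual scatter. Compound 4 is estimated at 200000 nM, within a range from 100000 nM to 400000 nM, most likely reported again as a limit.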

Compound 4, half-maximal cytotoxic concentration: 35300 nM
Beside the measured number, compound 4's estimate is 5.7-fold (0.75 log units) above it, outside the stated range (below it).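

Within the data shown here, replacing the 3-bromopropyl group with hydrogen on this aromatic carbon, next to the ring sulfur, gives the first readable step in this assay: an at least 5.6-fold lower number from compound 3 to compound 4 (0.75 log units; beyond the scatter). This position therefore matters for how much compound the cells tolerate, which the earlier entries could not show. In this pair, the compound with a 3-bromopropyl group at both ends of the core is tolerated at higher amounts than the compound with that group at one end only. The full size of the step stays unknown because compound 3 stands at a limit of the assay: the limit of > 200000 nM in this assay, at which 1 of the 4 values shown sits.

The compounds shown do not tell whether the bromine or the carbon chain of the 3-bromopropyl group accounts for the step, and a plain propyl chain or a 3-aminopropyl chain at this position would separate the two. They also leave open whether removing one such chain has the same result on a core with fewer or more rings.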